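Hydrazone aryl change in the triazole thioether series

The source may report more compounds than this note shows. Statements on the series, on what has been measured and on what is new or still open speak of the compounds shown alone.

Two compounds of the shared core have been run in a functional assay on HepG2 cells (Homo sapiens) for inhibition, read by MTT assay, with a stated time of 48 h; a lower number here means a stronger inhibitor, a higher number a weaker inhibitor. Compound 1, `O=[N+]([O-])c1ccc(CSc2nnc(-c3ccncc3)n2-c2ccccc2)cc1`, gives > 50000 nM in this assay, which is a limit and not a number. Compound 2, `O=C(CSc1nnc(-c2ccncc2)n1-c1ccccc1)N/N=C/c1ccc(Br)cc1`, gives 5990 nM in this assay. Compound 2 therefore holds the only number shown in this assay; the remaining result is the limit of > 50000 nM in this assay, at which 1 of the 2 values shown sits. Among the measured compounds shown here, no two measured compounds differ in a single place, so no measured step is available to lean on.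

Compound 3, `O=C(CSc1nnc(-c2ccncc2)n1-c1ccccc1)N/N=C/c1cc(Br)cc(Br)c1O`, is not yet measured. It differs from compound 2 by 3,5-dibromo-2-hydroxyphenyl in place of 4-bromophenyl on a carbon with a double bond to nitrogen. For the measured compounds named here, with no measured step of this kind to calibrate against, the expected change from compound 2 to compound 3 in this assay is a 1.7-fold lower number from compound 2 to compound 3 (0.23 log units; within the scatter), estimated as a move toward a lower number that may not clear the usual scatter. Compound 3 is expected to give about 3500 nM in this assay, with the estimate spanning 1200 nM to 12000 nM.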

Compound 3, half-maximal inhibitory concentration: 7590 nM
Estimate against measurement, compound 3: 2.2-fold (0.34 log units) below; the measured number falls inside the stated range.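

In this assay the aryl group on the carbon with a double bond to nitrogen now has its first readable step, a 1.3-fold higher number from compound 2 to compound 3 (0.10 log units; within the scatter). The values of compound 2 and compound 3 cannot be told apart in this read-out, even though 3,5-dibromo-2-hydroxyphenyl brings a second bromine, a hydrogen-bond donor and a hydrogen-bond acceptor that 4-bromophenyl lacks, so this particular exchange gives no measurable gain or loss at this place. Nothing on hand points to a cause for this outcome, and the step is read here only as a size.

A single step within the scatter leaves open whether any group at this place can move the number beyond the scatter, for instance a phenyl ring carrying an amine or a carboxylic acid, or a longer alkyl chain in place of the aryl ring. In this assay compound 1 gives > 50000 nM, which is a limit and not a number, and steps involving it cannot be read.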